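Notes on the aryl substituent step toward compound 3

This account rests on a few compounds, and the source may have more. Where it says the series, first, only, none or still open, it means among the compounds named here.

Compound 1 `Clc1cccc(-n2cc(CSc3nc4ccccc4s3)nn2)c1`: 39.6%
Compound 2 `Fc1ccc(-n2cc(CSc3nc4ccccc4s3)nn2)cc1`: 81.1%

In a functional assay on the whole organism (strain Albino Wistar) for inhibition, with Rattus norvegicus as the target, read by paw edema, with stated times of 1 h and 5 h, at a dose of 10 mg/kg by the oral route (a lower number here means less inhibition, a higher number more inhibition at the dose given (going by the name of the read-out)), compound 2 stands highest of the two numbers. Going by the values given here, the only measured step, a number 41.5 percentage points higher from compound 1 to compound 2 (beyond the scatter), is 4-fluorophenyl in place of 3-chlorophenyl on an aromatic nitrogen. Compound 3 `O=[N+]([O-])c1ccc(-n2cc(CSc3nc4ccccc4s3)nn2)cc1` differs from compound 2 by nitro in place of fluoro on an aromatic carbon. No measured step exchanges fluoro for nitro, so nothing bears on it directly; the single step shown only indicates that a change on this ring can move the read-out widely. The step to compound 3 is expected to be a number 21.1 percentage points lower from compound 2 to compound 3 (beyond the scatter), with wide uncertainty either way. Compound 3 is estimated at 60%, within 35% to 85%.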

Compound 3, a percentage reported as inhibition, in the whole organism at one dose (the size of the read-out at that dose, not a potency): 65.5%
The estimate for compound 3 lay 5.5 percentage points below the measured number, within the range that was stated.
By their numbers in this assay, from the lowest: compound 1; then compound 3; then compound 2.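

Unlike the earlier step, which changed both the group and its place, this one keeps the place fixed: on an aromatic carbon para to a large group, nitro in place of fluoro gives a number 15.6 percentage points lower from compound 2 to compound 3 (beyond the scatter) in this assay. The group with 3 heavy atoms in place of 1 costs part of the read-out, yet compound 3 still stands at 65.5% on this measure. Nothing available accounts for the size of this step.

From the compounds shown here alone, whether an amine or a carboxylic acid on this same carbon would give a higher or lower read-out stays open.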